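Swapping a methyl for a chlorine on the anilide ring

The source may hold more compounds than are shown below. What is called first, only, known or untested is meant among the compounds shown, and "the series" means these compounds.

Measured compounds:
- compound 1, `Cc1cccc(NC(=O)CSC(=S)N[C@H]2CCOC2=O)c1C`: > 128000 nM
- compound 2, `Cc1cccc(NC(=O)CSC(=S)N[C@H]2CCOC2=O)c1`: 63200 nM
- compound 3, `O=C(CSC(=S)N[C@H]1CCOC1=O)Nc1ccccc1`: > 128000 nM

Three compounds share one core and differ only in the aromatic ring on the amide nitrogen. Going by the values given here, in a functional assay on MCF7 cells (Homo sapiens) for cytotoxicity, read by MTT assay, with a stated time of 72 h (a higher number here means a weaker inhibitor, a lower number a stronger inhibitor), compound 2 gives 63200 nM and is the only one with a number rather than a limit. Compound 1 reaches only the limit of > 128000 nM in this assay. Compound 3 likewise reaches only the limit of > 128000 nM in this assay. Removing a methyl gave an at least 2.0-fold lower number from compound 1 to compound 2 (0.30 log units; that floor lies within the scatter), and removing the remaining methyl gave an at least 2.0-fold higher number from compound 2 to compound 3 (0.30 log units; that floor lies within the scatter); both steps end or begin at the limit of > 128000 nM in this assay, at which 2 of the 3 values shown sit, so their true size is not known.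

Compound 4, `O=C(CSC(=S)N[C@H]1CCOC1=O)Nc1ccccc1Cl`, has not been measured. It differs from compound 2 by 2-chlorophenyl in place of 3-methylphenyl on an amide-type nitrogen. The measured steps show that changing the aromatic substitution of compound 2 twice ended at the limit, so a weaker result than compound 2 is expected, with a 1.6-fold higher number from compound 2 to compound 4 (0.20 log units; within the scatter), and compound 4 is estimated at 100000 nM within 30000 nM to 300000 nM.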

Compound 4, half-maximal inhibitory concentration: 90800 nM
Beside the measured number, compound 4's estimate is 1.1-fold (0.04 log units) above it, and the stated range covers the measured number.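

In this assay, replacing 3-methylphenyl with 2-chlorophenyl on the amide-type nitrogen gave a 1.4-fold higher number from compound 2 to compound 4 (0.16 log units; within the scatter), so the two compounds cannot be told apart, and a methyl group is not needed for a measurable value in this small set. Adding chloro to the unsubstituted ring gave an at least 1.4-fold lower number from compound 3 to compound 4 (0.14 log units; that floor lies within the scatter), and the true size of this step is unknown. Compound 3 and compound 1 each remain at a limit, not a number: the limit of > 128000 nM in this assay, at which 2 of the 4 values shown sit.

The step from compound 2 to compound 4 changes both the group and its place on the ring, so the contribution of each remains unresolved. As far as these compounds go, how a methoxy group, an amine or a carboxylic acid on the ring would read in this assay also remains open.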